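Adding a Third Bromine to a Chalcone Pair

The source may hold more compounds than are shown below. What is called first, only, known or untested is meant among the compounds shown, and "the series" means these compounds.

Measured so far:
- Compound 1, `Cc1cc(O)c(C(=O)/C=C/c2ccc(Br)cc2)c(-c2ccccc2)c1C(=O)/C=C/c1ccc(Br)cc1`: 10000 nM
- Compound 2, `Cc1cc(O)c(C(=O)/C=C/c2ccc3ccccc3c2)c(-c2ccccc2)c1C(=O)/C=C/c1ccc2ccccc2c1`: 30000 nM

In a functional assay on MDA-MB-231 cells (Homo sapiens) for cytotoxicity, read by MTT assay, with a stated time of 24 h (on this read-out higher numbers stand for weaker inhibition and lower numbers for stronger inhibition), compound 1 gives 10000 nM, the lowest of the two numbers. Compound 2, in which each bromophenyl arm is replaced by a naphthyl arm, gives 30000 nM in this assay, a gap beyond the usual scatter, so compound 1 is the stronger of the two.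

Compound 3, `Cc1cc(O)c(C(=O)/C=C/c2ccc(Br)cc2)c(-c2ccc(Br)cc2)c1C(=O)/C=C/c1ccc(Br)cc1`, is not yet measured. It differs from compound 1 in one place: bromo in place of hydrogen on an aromatic carbon. Cut one bond further out, the change reads phenyl to 4-bromophenyl, sitting para to a large group on the shared core.

For the measured compounds named here, no measured pair shows this kind of change, so there is no step to lean on. A single bromine added on a ring that is otherwise unchanged is expected to move the number little, and the expected step of no change at the digits printed from compound 1 to compound 3 (within the scatter) is estimated to lie within the scatter. Compound 3 is therefore expected to give about 10000 nM in this assay, between 4000 nM and 30000 nM.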

Compound 3, half-maximal inhibitory concentration: 18000 nM
Compound 3: middle estimate off by 1.8-fold (0.26 log units), on the low side, and the stated range covers the measured number.
By their numbers in this assay, from the lowest: compounds 1, 3 and 2 (each within the scatter of the next, the first and the last beyond it).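

For the compounds shown here, this is the first test of the phenyl ring on the shared core, which carries no substituent in compound 1 or compound 2. In this assay, placing bromo in place of hydrogen on an aromatic carbon of this ring, para to a large group, gives a 1.8-fold higher number from compound 1 to compound 3 (0.26 log units; within the scatter), so the two numbers cannot be told apart and this single bromine has no readable effect at this position. No measurement of any property of these compounds bears on this result.

On these data alone, it remains open whether a different group at the same place, such as an amine, a carboxylic acid or a longer alkyl chain, would give a step beyond the scatter. Also open, as far as these compounds go, is whether 4-bromophenyl at this position would give a similar result with the naphthyl arms of compound 2.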